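Fluoro for trifluoromethyl: expected clearance of compound 3

The source may report more compounds than this note shows. Statements on the series, on what has been measured and on what is new or still open speak of the compounds shown alone.

Measured so far in an ADME assay on microsomes from liver (Mus musculus, strain NMRI) for metabolic stability, tested at 2.5 uM; on this read-out higher numbers stand for fast clearance and lower numbers for slow clearance:
compound 1 `Clc1ccc(-c2ccc(Cn3nnc4ccccc43)cc2)c(Cl)c1`: 1.3 mL/min/g
compound 2 `FC(F)(F)c1cc(Br)c2nnn(CC3CC3)c2c1`: 7.7 mL/min/g

Compound 1 gives 1.3 mL/min/g in this assay. Compound 2 gives 7.7 mL/min/g, the higher of the two numbers, and its gap to compound 1 lies beyond the usual scatter of this assay. For the measured compounds named here, the two share no common core, so the pair gives no step to read.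

Compound 3 `Fc1cc(Br)c2nnn(CC3CC3)c2c1` is not yet measured. It differs from compound 2 in one place: fluoro in place of trifluoromethyl on an aromatic carbon. Going by the values given here, no measured pair shows this change, so the direction of the step rests on no measured number, and the exchange of trifluoromethyl for fluoro is treated here as a small step. The step of a 1.3-fold lower number from compound 2 to compound 3 (0.11 log units; within the scatter) is expected to stay within the usual scatter, tending slightly lower. Compound 3 is estimated at 6 mL/min/g in this assay, with a range of 2.5 mL/min/g to 13 mL/min/g.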

Compound 3, intrinsic clearance in a liver preparation (reported as CLH), per the amount of preparation that the assay uses: 5.7 mL/min/g
Beside the measured number, compound 3's estimate is 1.1-fold (0.02 log units) above it; measured number inside the range.
By their numbers in this assay, from the lowest: compound 1; then compounds 3 and 2 (each within the scatter of the next).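

In this assay, for the compounds shown here, fluoro in place of trifluoromethyl on this aromatic carbon gives a 1.4-fold lower number from compound 2 to compound 3 (0.13 log units; within the scatter), the only measured reading of this change. At this position, para to a fused ring and meta to the bromo group, the two groups therefore cannot be told apart on clearance, although this rests on a single pair with the rest of the structure held constant. No measured property available here bears on this result.

From the compounds shown here alone, whether an amine, a carboxylic acid or a longer chain on this same carbon would give a step beyond the scatter remains open. Also open, going by these compounds, is whether the exchange of trifluoromethyl for fluoro would read the same on another core, such as that of compound 1.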